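From Compound 3 to Compound 4: A New Ring on the Chain

The compounds below may be only part of what the source reports. "The series", "measured", "known", "first", "only" and "open" are said of these compounds alone.

Compound 1 `CN1CCN(CCOc2nn(-c3ccccc3F)c3ccc(F)cc23)C1=O`, compound 2 `O=C1NCCN1CCOc1nn(-c2ccccc2F)c2ccc(F)cc12` and compound 3 `O=C1OCCN1CCOc1nn(-c2ccccc2F)c2ccc(F)cc12` share one core and differ only in the ring carried on the side chain. In an ADME assay on liver for metabolic stability, with Liver microsome (Rattus norvegicus) as the target, using microsomes and NADPH, with a stated time of 30 min, tested at 0.5 uM (on this read-out higher numbers stand for fast clearance and lower numbers for slow clearance), compound 1 gives 7200 mL/min/kg, compound 2 gives 1380 mL/min/kg and compound 3 gives 2480 mL/min/kg. Compound 3 therefore lies clearly under compound 1, with a 2.9-fold lower number from compound 1 to compound 3 (0.46 log units; beyond the scatter), but cannot be told apart from compound 2, with a 1.8-fold higher number from compound 2 to compound 3 (0.25 log units; within the scatter).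

Compound 4 `Fc1ccc2c(c1)c(OCCn1ccnc1)nn2-c1ccccc1F` keeps the core and chain but carries 1H-imidazol-1-yl in place of 2-oxo-1,3-oxazolidin-3-yl on a saturated chain carbon, two bonds along the chain from an oxygen on an aromatic ring. The nearest guides are the two swaps at this same place, already cited, along with the smaller edit in a 5.2-fold lower number from compound 1 to compound 2 (0.72 log units; beyond the scatter). These steps range from within the scatter to modest, and none introduces an aromatic ring here, so they indicate no direction. The expected result in this assay is a 1.0-fold higher number from compound 3 to compound 4 (0.00 log units; within the scatter), with no step beyond the scatter anticipated. The estimate for compound 4 is 2500 mL/min/kg, within an expected range of 1000 mL/min/kg to 6500 mL/min/kg.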

Compound 4, clearance: 1150 mL/min/kg
For compound 4 the middle estimate is 2.2-fold (0.34 log units) above the measured one, and the stated range covers the measured number.
By their numbers in this assay, from the lowest: compounds 4, 2 and 3 (each within the scatter of the next, the first and the last beyond it); then compound 1.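

In this assay, a five-membered aromatic ring works on this chain, which the three non-aromatic rings could not show. The 1H-imidazol-1-yl group gives a clear drop against the 2-oxo-1,3-oxazolidin-3-yl group (a 2.2-fold lower number from compound 3 to compound 4 (0.33 log units; beyond the scatter)) and a larger one against the 3-methyl-2-oxoimidazolidin-1-yl group (a 6.3-fold lower number from compound 1 to compound 4 (0.80 log units; beyond the scatter)), yet it cannot be told apart from the 2-oxoimidazolidin-1-yl group (a 1.2-fold lower number from compound 2 to compound 4 (0.08 log units; within the scatter)), so the ring carbonyl is not needed for a number this low. Nothing here explains why the aromatic ring behaves this way.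

From the compounds shown here alone, whether this extends to other aromatic rings, such as a pyrazole or a 1,2,4-triazole, remains open. So does the effect of an open-chain amine at this place, or of a longer chain carrying the imidazole.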